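Phenyl for Hydroxy on a Fused Aromatic Core

The source may report more compounds than this note shows. Statements on the series, on what has been measured and on what is new or still open speak of the compounds shown alone.

Measured compounds:
compound 1, `CN1CCC[C@H]1[C@@H]1COc2cc(O)ccc2O1`, 50000 nM
compound 2, `CN1CCC[C@H]1[C@H]1COc2c(O)cccc2O1`, 1700 nM
compound 3, `CN1CCC[C@H]1[C@@H]1COc2cc(-c3ccccc3)ccc2O1`, 59000 nM

In an assay on membranes from Cerebral cortex for displacement of a labelled ligand from Neuronal acetylcholine receptor; alpha4/beta2 (Rattus norvegicus), with a stated time of 5 min (a lower number here means a stronger inhibitor, a higher number a weaker inhibitor), compound 2 gives the lowest number of the three, with compound 1 and compound 3 both far weaker, their steps to compound 2 beyond the scatter. Compound 1 and compound 2 share the same atoms joined differently; the difference between the two cores is not broken down here.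

From compound 1 to compound 3 the change is phenyl in place of hydroxy on an aromatic carbon and the step is a 1.2-fold higher number from compound 1 to compound 3 (0.07 log units; within the scatter).

Compound 4, `CN1CCC[C@H]1[C@H]1COc2c(cccc2-c2ccccc2)O1`, has not been measured. It differs from compound 2 by phenyl in place of hydroxy on an aromatic carbon. This is the same kind of change as from compound 1 to compound 3, but the place differs: in compound 4 the phenyl sits ortho to a fused ring and meta to a fused ring, whereas in compound 3 it sits meta to a fused ring and para to a fused ring. Because the measured step of a 1.2-fold higher number from compound 1 to compound 3 (0.07 log units; within the scatter) was within the scatter, a small step might be expected, but that precedent was at a different place and started from a weak compound. The estimated step from compound 2 to compound 4 in this assay is a 3.5-fold higher number from compound 2 to compound 4 (0.55 log units; beyond the scatter). Compound 4 is expected to give about 6000 nM, most likely between 1500 nM and 30000 nM.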

Compound 4, inhibition constant: 7300 nM
The estimate for compound 4 lay 1.2-fold (0.09 log units) below the measured number, within the range that was stated.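

In this assay, phenyl in place of hydroxy on the core of compound 2 gives a 4.3-fold higher number from compound 2 to compound 4 (0.63 log units; beyond the scatter), a modest but real loss. Set beside the earlier pair, the size of this step does not carry over unchanged from one core to the other: the same change on two cores in this assay, a 1.2-fold higher number (0.07 log units; within the scatter) from compound 1 to compound 3 and a 4.3-fold higher number (0.63 log units; beyond the scatter) from compound 2 to compound 4, 3.6-fold (0.56 log units) apart, beyond the scatter of two such steps This rests on only two pairs, which differ both in the core and in where the phenyl sits, so the compounds do not show which of these sets the size of the step, nor why the two steps differ; the earlier pair also starts from a weak compound, with compound 1 at 50000 nM.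

From the compounds shown here alone, it remains open how a methoxy group, an amine or a carboxylic acid in place of the hydroxy of compound 2 would compare with compound 4. Going by these compounds, it also remains open whether phenyl, placed on the core of compound 2 where it sits in compound 3, would give a step closer to the earlier one.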